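Removing the Methyl from the Weakest Compound

The source may hold more compounds than are shown below. What is called first, only, known or untested is meant among the compounds shown, and "the series" means these compounds.

Compound 1 `O=c1[nH]c2ccccc2cc1/C=N/O`: 31800 nM
Compound 2 `Cc1ccc2[nH]c(=O)c(/C=N/Nc3ccc([N+](=O)[O-])cc3)cc2c1`: 8250 nM
Compound 3 `Cc1ccc2[nH]c(=O)c(/C=N/Nc3ccc([N+](=O)[O-])cc3[N+](=O)[O-])cc2c1`: 144000 nM

In a functional assay, read by spectrophotometry, with a stated time of 3 min (on this read-out lower numbers stand for stronger inhibition and higher numbers for weaker inhibition), compound 3 gives the highest number of the three, so it is the weakest inhibitor here, with compound 1 nearest and compound 2 furthest. Among the measured compounds shown here, the only single-place step among the measured compounds is a 17-fold higher number from compound 2 to compound 3 (1.24 log units; beyond the scatter), a nitro group added to the hydrazone aryl ring. Compound 4 `O=c1[nH]c2ccccc2cc1/C=N/Nc1ccc([N+](=O)[O-])cc1[N+](=O)[O-]` differs from compound 3 by hydrogen in place of methyl on an aromatic carbon. No measured step involves this methyl alone, since compound 1 also differs elsewhere, so nothing shown bears directly on it. The expected step is therefore a 1.0-fold lower number from compound 3 to compound 4 (0.01 log units; within the scatter), none beyond the scatter. Compound 4 is estimated at 140000 nM, within 50000 nM to 400000 nM.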

Compound 4, half-maximal inhibitory concentration: 142000 nM
The estimate for compound 4 lay 1.0-fold (0.01 log units) below the measured number, within the range that was stated.
By their numbers in this assay, from the lowest: compound 2; then compound 1; then compounds 4 and 3 (each within the scatter of the next).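

In this assay, among the compounds shown here, hydrogen in place of methyl on this aromatic carbon gives a 1.0-fold lower number from compound 3 to compound 4 (0.01 log units; within the scatter), the first step to isolate this methyl. For this pair, then, the read-out does not tell methyl from hydrogen at this position. No measurement here offers an explanation for this result.

From the compounds shown here alone, whether an ethyl, a methoxy or an amine on the same carbon would shift the number remains open. So does whether removing the methyl from compound 2, a much stronger inhibitor, would likewise stay within the scatter.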